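Chloromethyl for ethylamino at the ring carbon of compound 3

This account rests on a few compounds, and the source may have more. Where it says the series, first, only, none or still open, it means among the compounds named here.

Measured so far in an assay on isolated protein (strain Sprague-Dawley) for inhibition of Amine oxidase [flavin-containing] B (Rattus norvegicus), read by spectrophotometry, with a stated time of 5 min; on this read-out lower numbers stand for stronger inhibition and higher numbers for weaker inhibition:
compound 1 `CC(=O)COc1cc(=O)oc2cc(OCc3cccc(Cl)c3)ccc12` gives 26.9 nM
compound 2 `O=C(COc1cc(=O)oc2cc(OCc3cccc(Cl)c3)ccc12)N1CCCCC1` gives 38900 nM
compound 3 `CCNc1cc(=O)oc2cc(OCc3cccc(Cl)c3)ccc12` gives 28.2 nM

Compound 3 holds the second highest of the three numbers. Its nearest neighbour is compound 1, with a 1.0-fold higher number from compound 1 to compound 3 (0.02 log units; within the scatter); the two cannot be told apart. The furthest is compound 2, with a 1400-fold lower number from compound 2 to compound 3 (3.14 log units; beyond the scatter), a large step.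

Compound 4 `O=c1cc(CCl)c2ccc(OCc3cccc(Cl)c3)cc2o1` has not yet been measured. Compared with compound 3 the change is chloromethyl in place of ethylamino on an aromatic carbon.

For the measured compounds named here, three measured steps bear on this position. The step of a 1.0-fold higher number from compound 1 to compound 3 (0.02 log units; within the scatter) exchanges two groups without a ring at the same aromatic carbon and stays within the scatter. The steps of a 1400-fold higher number from compound 1 to compound 2 (3.16 log units; beyond the scatter) and a 1400-fold lower number from compound 2 to compound 3 (3.14 log units; beyond the scatter) are the only large ones, and both involve the piperidin-1-yl group entering or leaving. Chloromethyl carries no ring and is smaller than either group that has been exchanged without effect, so no step beyond the scatter is expected: the estimated move is a 1.2-fold higher number from compound 3 to compound 4 (0.09 log units; within the scatter). Going by the values given here, no measured compound carries a halogen on this carbon, so the range is kept wide.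

Compound 4 is thus expected to give about 35 nM in this assay, with a range from 8 nM to 150 nM.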

Compound 4, half-maximal inhibitory concentration: 43.7 nM
Compound 4: the middle estimate sits 1.2-fold (0.10 log units) below what was measured; low and high end bracket the measured number.
By their numbers in this assay, from the lowest: compounds 1, 3 and 4 (each within the scatter of the next); then compound 2.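

In this assay, a 1.5-fold higher number from compound 3 to compound 4 (0.19 log units; within the scatter) and a 1.6-fold higher number from compound 1 to compound 4 (0.21 log units; within the scatter), so at this aromatic carbon opposite the ring oxygen chloromethyl, which has no hydrogen-bond donor or acceptor, cannot be told apart from ethylamino or 2-oxopropoxy. Across these three compounds, neither the nitrogen and its hydrogen-bond donor nor the oxygen link to this carbon is needed to keep the number in the same range, and a chlorine in the group at this carbon is compatible with that range. For the compounds shown here, the one large new step is an 890-fold lower number from compound 2 to compound 4 (2.95 log units; beyond the scatter), which leaves ((piperidin-1-yl)carbonyl)methoxy as the only group at this carbon linked to a large change, and no measurement on hand accounts for that difference or for the flat behaviour of the other three groups.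

Going by these compounds, it remains open whether the large change follows the piperidine ring or the amide, which a small amide such as the dimethylamide, or a carboxylic acid on the same oxymethyl link, would separate. Also open, on these data alone, is how far the flat range extends at this carbon, for example to plain methyl, hydroxymethyl, a longer alkyl chain or a free primary amine.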